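The source may report more compounds than this note shows. Statements on the series, on what has been measured and on what is new or still open speak of the compounds shown alone.

In an ADME assay on cells (Homo sapiens) for cytotoxicity, read by resazurin assay, with a stated time of 5 days (on this read-out lower numbers stand for higher toxicity in this test and higher numbers for lower toxicity in this test), compound 2 `O=S(=O)(Cc1nc(-c2ccc(F)nc2)c2sccc2n1)c1cccc(Cl)c1` gives 40000 nM and compound 1 `COc1ccc(Nc2nc(CS(=O)(=O)c3cccc(Cl)c3)nc3ccsc23)cc1` gives 60000 nM as its value, so the two lie within the scatter of each other. Compound 3 `COc1ccc(Oc2nc(CS(=O)(=O)c3cccc(Cl)c3)nc3ccsc23)cc1` carries 4-methoxyphenoxy in place of 6-fluoropyridin-3-yl on an aromatic carbon. For the measured compounds named here, the only measured step at this place, a 1.5-fold lower number from compound 1 to compound 2 (0.18 log units; within the scatter) on exchanging (4-methoxyphenyl)amino for 6-fluoropyridin-3-yl, stays within the scatter, so no step beyond the scatter is expected in this assay here. The expected step is a 1.1-fold higher number from compound 2 to compound 3 (0.05 log units; within the scatter) in size. For compound 3 the estimate is 45000 nM with an expected range from 18000 nM to 100000 nM as its span.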

Compound 3, half-maximal cytotoxic concentration: > 50000 nM
Compound 3: only a limit was reported; the forecaster's own chance of this, stated with the estimate: 20%; middle value at least 1.1-fold (0.04 log units) away from the limit.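

In this assay, for the compounds shown here, a third aryl group, 4-methoxyphenoxy, now sits on this aromatic carbon, and the exchange gives an at least 1.2-fold higher number from compound 2 to compound 3 (0.09 log units; that floor lies within the scatter) as the only readable step, so it cannot be told whether the change goes beyond the scatter. The step from compound 1 to compound 3 cannot be read. The value of compound 3 is a limit, not a number: the limit of > 50000 nM in this assay, at which 1 of the 3 values shown sits.

As far as these compounds go, what a carboxylic acid or a morpholine on this aromatic carbon would give stays open. From the compounds shown here alone, the true value of compound 3 also stays open.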